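The source may report more compounds than this note shows. Statements on the series, on what has been measured and on what is new or still open speak of the compounds shown alone.

Measured compounds in a physicochemical assay for lipophilicity, using the shake flask method, measured as octanol-water partition, with a stated time of 24 h, at 25 degrees C; on this read-out higher numbers stand for higher lipophilicity and lower numbers for lower lipophilicity:
compound 1, `Fc1ccccc1CN(Cc1nnn[nH]1)c1ccccc1` — compound 1 gives 1.28;
compound 2, `CCCCCCCCN(Cc1nnn[nH]1)c1ccccc1` — compound 2 gives 2.24;
compound 3, `COc1ccc(N(Cc2nnn[nH]2)Cc2ccc(F)cc2F)cc1` — compound 3 gives 1.37.

Compound 2 stands highest of the three in this assay; compound 3 lies nearest and compound 1 furthest, both beyond the scatter. Compound 4, `Fc1cccc(CN(Cc2nnn[nH]2)c2ccccc2)c1`, differs from compound 2 by 3-fluorophenyl in place of heptyl on a saturated chain carbon bound to a nitrogen on an aromatic ring. Among the compounds with values here, the one measured step that bears on this change runs the other way: a number 0.96 log units higher from compound 1 to compound 2 (beyond the scatter). Reversing it, compound 4 is expected to sit well below compound 2, the expected step being a number 0.94 log units lower from compound 2 to compound 4 (beyond the scatter), close to where compound 1 stands in this assay. The estimate for compound 4 is therefore 1.3, with a range of 0.9 to 1.7.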

Compound 4, partition coefficient: 1.29
Beside the measured number, compound 4's estimate is 0.01 log units above it, and the stated range covers the measured number.
By their numbers in this assay, from the lowest: compounds 1, 4 and 3 (each within the scatter of the next); then compound 2.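

In this assay, the drop on leaving heptyl now appears with a second fluorophenyl group, a number 0.95 log units lower from compound 2 to compound 4 (beyond the scatter), so it is no longer tied to 2-fluorophenyl alone. The comparison of the two fluorophenyl groups, a number 0.01 log units higher from compound 1 to compound 4 (within the scatter), shows that 3-fluorophenyl in place of 2-fluorophenyl leaves no readable difference at this position. Nothing given here accounts for these numbers. Still open, from the compounds shown here alone, is how a group without fluorine, such as plain phenyl, would compare with these two fluorophenyl groups at this position. A cyclohexyl ring or a carboxylic acid there also remains untested in the compounds shown.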